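This account rests on a few compounds, and the source may have more. Where it says the series, first, only, none or still open, it means among the compounds named here.

Of the compounds shown here, three built on one shared core have been tested in a functional assay on HT-29 cells (Homo sapiens) for cytotoxicity, read by MTT assay; a lower number here means a stronger inhibitor, a higher number a weaker inhibitor. Compound 1 `C/C(=C\Cc1c(O)ccc2c1O[C@H](c1ccc(O)cc1)CC2=O)C/C=C/C(C)(C)O` gives > 10000 nM, which is a limit of the assay rather than a number. Compound 2 `C=C(C)C(O)CC/C(C)=C/Cc1c(O)ccc2c1O[C@H](c1ccc(O)cc1)CC2=O` gives > 10000 nM, again a limit. Compound 3 `C=C(CCC=C(C)C)C(O)Cc1c(O)ccc2c1O[C@H](c1ccc(O)cc1)CC2=O` gives > 10000 nM, also a limit. Because (the limit of > 10000 nM in this assay, at which 3 of the 3 values shown sit), none of the comparisons among these three can be read: a step that the two limits leave unreadable from compound 1 to compound 2, a step that the two limits leave unreadable from compound 1 to compound 3 and a step that the two limits leave unreadable from compound 2 to compound 3 all remain of unreadable size. Compound 3 therefore stands exactly where its two companions stand, at the limit, with no measured separation from either of them.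

Compound 4 `CC1=CCC(O)C(C)(C)C1Cc1c(O)ccc2c1O[C@H](c1ccc(O)cc1)CC2=O` has not yet been measured. It differs from compound 3 in that (a group of 10 heavy atoms (9 carbon, 1 oxygen; one six-membered non-aromatic ring of carbon only) in place of a group of 10 heavy atoms (9 carbon, 1 oxygen; no ring), on a saturated chain carbon bound to an aromatic carbon); the two share the same atoms, joined differently. Among the measured compounds shown here, no measured step bears directly on a change of this kind, and the three measured compounds, each carrying a different open chain at the same place, all sit at the limit. The expectation is that compound 4 will also sit at or near that limit, with the step that the limit leaves unreadable from compound 3 to compound 4 expected to be small or not readable. In this assay compound 4 is estimated at 15000 nM, within a range from 5000 nM to 50000 nM.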

Compound 4, half-maximal inhibitory concentration: > 10000 nM
Compound 4 ended at the assay's limit; the forecaster's own chance of this, stated with the estimate: 80%; the middle value is on the limit's open side.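

Compound 4 also sits at a limit of the assay, so its steps from compound 1, compound 2 and compound 3 cannot be read: the limit of > 10000 nM in this assay, at which 4 of the 4 values shown sit.

As far as these compounds go, whether the six-membered ring of compound 4 and the open chains of compound 1, compound 2 and compound 3 differ at all in this assay stays open, as does the actual strength of any of the four.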